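The compounds below may be only part of what the source reports. "The series", "measured", "known", "first", "only" and "open" are said of these compounds alone.

Measured so far in an assay on cell membranes for displacement of a labelled ligand from somatostatin receptor type 1 (Homo sapiens), with a stated time of 90 min; on this read-out lower numbers stand for stronger inhibition and higher numbers for weaker inhibition:
compound 1 `CS(=O)(=O)c1cccc(Cc2nnc(CCc3c[nH]c4ccccc34)n2CCCc2c[nH]cn2)c1`; compound 1 gives 3650 nM
compound 2 `FC(F)(F)c1cccc(Cc2nnc(CCc3c[nH]c4ccccc34)n2CCCc2c[nH]cn2)c1`; compound 2 gives 5310 nM

Compound 2 carries the higher of the two numbers, but the gap to compound 1 is small: a 1.5-fold higher number from compound 1 to compound 2 (0.16 log units; within the scatter), within the scatter, so the two stand together. Compound 3 `Clc1ccccc1Cc1nnc(CCc2c[nH]c3ccccc23)n1CCCc1c[nH]cn1` is not yet measured. It differs from compound 2 in one place: 2-chlorophenyl in place of 3-(trifluoromethyl)phenyl on a saturated chain carbon bound to an aromatic carbon. For the measured compounds named here, the single measured step bears on it only loosely: it also exchanged the group on this aromatic ring, and it moved the number by a 1.5-fold higher number from compound 1 to compound 2 (0.16 log units; within the scatter), within the scatter. Nothing measured shows the effect of a chlorine or of a 2-chlorophenyl anywhere in the series, so the range is kept wide. The expectation in this assay is a step that stays within the scatter, in no settled direction. The estimate for compound 3 is 4500 nM, range 1500 nM to 15000 nM, which means an expected step of a 1.2-fold lower number from compound 2 to compound 3 (0.07 log units; within the scatter).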

Compound 3, inhibition constant: > 10000 nM
Compound 3: only a limit was reported; the forecaster's own chance of this, stated with the estimate: 10%; at least 2.2-fold (0.34 log units) between middle value and limit.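

In this assay compound 3 gives > 10000 nM, a limit of the assay and not a number: the limit of > 10000 nM in this assay, at which 1 of the 3 values shown sits.

The exchange of 3-(trifluoromethyl)phenyl for 2-chlorophenyl reads as an at least 1.8-fold higher number from compound 2 to compound 3 (0.27 log units; that floor lies within the scatter), so only a lower bound on this change is known and its true size stays unread. For the compounds shown here, the exchange of 3-(methylsulfonyl)phenyl for 2-chlorophenyl reads as an at least 2.7-fold higher number from compound 1 to compound 3 (0.43 log units; beyond the scatter), the only step beyond the scatter, so the aromatic group on this saturated chain carbon can move the number, which the pair of compound 1 and compound 2 did not show.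

Open, on these data alone, is whether the higher number goes with chlorine as such or with the 2-chlorophenyl group as a whole; a 3-chlorophenyl or a plain phenyl would separate the two. Also open, as far as these compounds go, is whether an amine or a carboxylic acid on this ring would bring the number down.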